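Epoxide for diol on the pyrrolidine nitrogen

The source may report more compounds than this note shows. Statements on the series, on what has been measured and on what is new or still open speak of the compounds shown alone.

Of the compounds shown here, three have been measured in a functional assay on Daudi cells (Homo sapiens) for antiproliferative activity; on this read-out lower numbers stand for stronger inhibition and higher numbers for weaker inhibition. Compound 1 `Nc1ncnc2c1c(-c1cc3ccccc3o1)cn2[C@H]1CCN(C[C@H]2CO2)C1` gives 4210 nM, compound 3 `Nc1ncnc2c1c(-c1ccc(NC(=O)c3ccccc3)cc1)cn2[C@H]1CCN(C[C@@H]2CO2)C1` gives 3180 nM, and compound 2 `Nc1ncnc2c1c(-c1ccc(Oc3ccccc3)cc1)cn2C[C@H]1CCCN1C(CO)CO` gives 28200 nM. On these numbers compound 2 stands highest: its separation from compound 1 and from compound 3 lies beyond the usual scatter, so compound 2 is the weakest inhibitor of the three.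

Compound 4 `Nc1ncnc2c1c(-c1ccc(Oc3ccccc3)cc1)cn2C[C@H]1CCCN1C[C@@H]1CO1` has not yet been measured. It differs from compound 2 in one place: (oxiran-2-yl)methyl in place of 2-hydroxy-1-(hydroxymethyl)ethyl on an amine nitrogen in a ring. Among the compounds with values here, the two compounds that carry an (oxiran-2-yl)methyl group on a ring amine, compound 1 and compound 3, both show lower numbers than compound 2, but each of them also differs from compound 2 elsewhere, so no single step isolates this change.

The expectation for compound 4 is a move toward stronger inhibition, of moderate size and beyond the scatter, given as a 3.5-fold lower number from compound 2 to compound 4 (0.55 log units; beyond the scatter). Compound 4 is estimated at 8000 nM, within a range from 2500 nM to 25000 nM.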

Compound 4, half-maximal inhibitory concentration: 7040 nM
For compound 4 the middle estimate is 1.1-fold (0.06 log units) above the measured one, within the range that was stated.
By their numbers in this assay, from the lowest: compounds 3, 1 and 4 (each within the scatter of the next, the first and the last beyond it); then compound 2.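

Within the data shown here, compound 2 and compound 4 differ in one place, so a 4.0-fold lower number from compound 2 to compound 4 (0.60 log units; beyond the scatter) in this assay is the first reading of this change on its own, free of the other differences that separate compound 1 and compound 3 from compound 2. It shows that the group on this amine nitrogen in a ring matters for the read-out: with the rest of the structure held constant, (oxiran-2-yl)methyl gives a modestly lower number than 2-hydroxy-1-(hydroxymethyl)ethyl. Nothing available bears on which feature of the change lies behind this step.

The compounds shown leave open whether the three-membered ring itself is needed, as they offer no comparison with a plain propyl chain or a tertiary amine side chain on this nitrogen. They also leave open how the opposite configuration of the oxirane stereocentre would read in this series.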